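Swapping One Phenyl Substituent on a Weak Cell Growth Inhibitor

The compounds below may be only part of what the source reports. "The series", "measured", "known", "first", "only" and "open" are said of these compounds alone.

Going by the values given here, compound 2 `COc1ccc(Cn2nnc(O)c2C(=O)Nc2cccc(-c3ccc(O)cc3)c2)cc1` is one of two compounds measured in a functional assay on CWR22R cells (Homo sapiens) for inhibition, read by sulforhodamine B assay, with a stated time of 72 h; on this read-out lower numbers stand for stronger inhibition and higher numbers for weaker inhibition. In this assay, among the compounds with values here, compound 2 gives 67500 nM, the lowest of the two numbers, though only narrowly: compound 1 `COc1ccc(Cn2nnc(O)c2C(=O)Nc2cccc(C(F)(F)F)c2)cc1` gives 81400 nM, and the single measured step, a 1.2-fold lower number from compound 1 to compound 2 (0.08 log units; within the scatter), lies within the scatter. Compound 3 `COc1ccc(Cn2nnc(O)c2C(=O)Nc2cccc(-c3cccc(OC)c3)c2)cc1` has not yet been measured. It differs from compound 2 in one place: 3-methoxyphenyl in place of 4-hydroxyphenyl on an aromatic carbon. Within the data shown here, the one step that bears on this change is the step from compound 1 to compound 2, which also exchanged a group on an aromatic carbon without moving the number beyond the scatter. On that basis the expectation is that exchanging one six-membered aromatic ring of carbon only for another will likewise leave the read-out roughly where it stands, so for compound 3 the estimated step is a 1.0-fold higher number from compound 2 to compound 3 (0.02 log units; within the scatter). Compound 3 is therefore expected to give 70000 nM in this assay, with a likely range from 30000 nM to 160000 nM.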

Compound 3, half-maximal inhibitory concentration: 59000 nM
Compound 3: middle estimate off by 1.2-fold (0.07 log units), on the high side; the range from low to high includes it.
By their numbers in this assay, from the lowest: compounds 3, 2 and 1 (each within the scatter of the next).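

The exchange of 4-hydroxyphenyl for 3-methoxyphenyl on this aromatic carbon is a 1.1-fold lower number from compound 2 to compound 3 (0.06 log units; within the scatter) in this assay even though the group that leaves has 1 hydrogen-bond donor and the group that enters has 0 hydrogen-bond donors. The exchange of trifluoromethyl for 3-methoxyphenyl at this place is a 1.4-fold lower number from compound 1 to compound 3 (0.14 log units; within the scatter) and so, across the three compounds shown, none of these groups separates from the others beyond the scatter. No measurement at hand gives a reason for this flat picture.

Still open, as far as these compounds go, is whether any group at this place can move the number beyond the scatter, as an amine or a carboxylic acid on the outer phenyl ring might. The compounds shown also leave open whether a longer chain in place of that ring would do so.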